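Phenyl Sulfonyl Replaces Furanyl Carbonyl on the Shared Core

A few compounds are considered here, and "the series" means these few. Any claim that something is new, unique, unknown or untested is made for them only; others in the source may bear on it.

Three compounds with a shared core have been measured:
compound 1 `CC(=O)N(C)c1ccc2[nH]c(-c3n[nH]c4ccccc34)cc2n1` gives 10300 nM in a functional assay on KB cells (Homo sapiens) for antiproliferative activity, read by MTT assay, with a stated time of 72 h; on this read-out higher numbers stand for weaker inhibition and lower numbers for stronger inhibition;
compound 2 `CN(C(=O)c1ccccc1)c1ccc2[nH]c(-c3n[nH]c4ccccc34)cc2n1` gives 8580 nM;
compound 3 `CN(C(=O)c1ccco1)c1ccc2[nH]c(-c3n[nH]c4ccccc34)cc2n1` gives 19400 nM.

Compound 3 carries the highest of the three numbers. Its gap to compound 1, a 1.9-fold higher number from compound 1 to compound 3 (0.27 log units; within the scatter), is within the scatter, so these two cannot be told apart. Its gap to compound 2, a 2.3-fold higher number from compound 2 to compound 3 (0.35 log units; beyond the scatter), is beyond the scatter, so compound 3 inhibits less strongly than compound 2.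

Compound 4 `CN(c1ccc2[nH]c(-c3n[nH]c4ccccc34)cc2n1)S(=O)(=O)c1ccccc1` is the next step: phenylsulfonyl in place of (furan-2-yl)carbonyl on a nitrogen on an aromatic ring. The measured steps, a 1.2-fold lower number from compound 1 to compound 2 (0.08 log units; within the scatter) and a 2.3-fold higher number from compound 2 to compound 3 (0.35 log units; beyond the scatter), only swap the group on a carbonyl carbon; none of them exchanges the carbonyl itself for a sulfonyl. The phenyl ring of compound 2 comes back, yet joined through a sulfonyl, so the measured steps bear on it only loosely. All three numbers sit close together, and the phenyl-bearing compound 2 has the lowest, so a small drop in number is expected for compound 4, with wide uncertainty.

Compound 4 is therefore estimated at 12000 nM in this assay, between 4000 nM and 40000 nM. That estimate means an expected step of a 1.6-fold lower number from compound 3 to compound 4 (0.21 log units; within the scatter).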

Compound 4, half-maximal inhibitory concentration: 2400 nM
Compound 4: middle estimate off by 5.0-fold (0.70 log units), on the high side; the measured number lies below the stated range.
By their numbers in this assay, from the lowest: compound 4; then compounds 2, 1 and 3 (each within the scatter of the next, the first and the last beyond it).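

Swapping the carbonyl for a sulfonyl on this nitrogen on an aromatic ring has a larger effect in this assay than anything the earlier swaps of the group on the carbonyl carbon showed, and compound 4 inhibits more strongly than each of the other three compounds. The clearest comparison is with compound 2. In this pair the phenyl ring stays and only the carbonyl link gives way to the sulfonyl link (a 3.6-fold lower number from compound 2 to compound 4 (0.55 log units; beyond the scatter)), while the steps from the other two amides, which also change the ring or chain, are of similar order (a 4.3-fold lower number from compound 1 to compound 4 (0.63 log units; beyond the scatter) and an 8.1-fold lower number from compound 3 to compound 4 (0.91 log units; beyond the scatter)). No measurement available here explains why the sulfonyl compound gives the lower number.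

As far as these compounds go, with a single sulfonyl compound, it remains open whether the gain belongs to the sulfonyl link in general or only to phenylsulfonyl, a question that methylsulfonyl or (furan-2-yl)sulfonyl on the same nitrogen would address by direct pairing with compound 1 and compound 3. Also open, from the compounds shown here alone, is what the saturated chain carbon on that nitrogen contributes, since a hydrogen or an ethyl group in its place would test that.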